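Swapping the Amine on a Compound at the Assay Limit

This account rests on a few compounds, and the source may have more. Where it says the series, first, only, none or still open, it means among the compounds named here.

In a functional assay on A549 cells (Homo sapiens) for inhibition (on this read-out lower numbers stand for stronger inhibition and higher numbers for weaker inhibition), compound 3 `O=C(CC(CC(=O)NC1Cc2ccccc2C1)c1ccccc1)NCCN1CCCCC1` gives > 100000 nM, which is a limit of the assay and not a number.

Two relatives carry a chloro group where compound 3 has hydrogen. Compound 1 `O=C(CC(CC(=O)NC1Cc2ccccc2C1)c1ccc(Cl)cc1)NCCN1CCCCC1` gives 28000 nM, and compound 2 `O=C(CC(CC(=O)NC1Cc2ccccc2C1)c1ccc(Cl)cc1)NCCN1CCCC1` gives 50900 nM.

Compound 4 `CCN(CC)CCNC(=O)CC(CC(=O)NC1Cc2ccccc2C1)c1ccccc1` has not yet been measured. It differs from compound 3 by diethylamino in place of piperidin-1-yl on a saturated chain carbon, two bonds along the chain from an amide-type nitrogen: diethylamino in place of piperidin-1-yl.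

The closest measured change also replaces the amine, with pyrrolidin-1-yl in place of piperidin-1-yl, and it gave a 1.8-fold higher number from compound 1 to compound 2 (0.26 log units; within the scatter). The other measured change, hydrogen in place of chloro, gave an at least 3.5-fold higher number from compound 1 to compound 3 (0.55 log units; beyond the scatter), but it plays no part here, since compound 3 and compound 4 both carry hydrogen at that spot.

Going by the amine swap from compound 1 to compound 2, no shift beyond the scatter is expected in this assay. The expected change is a number no higher from compound 3 to compound 4 (the limit leaves the size open). Compound 4 may well return only a limit too. For compound 4 the estimated value is 100000 nM, with an expected range from 50000 nM to 200000 nM.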

Compound 4, half-maximal inhibitory concentration: 82400 nM
Beside the measured number, compound 4's estimate is 1.2-fold (0.08 log units) above it, and the stated range covers the measured number.
By their numbers in this assay, from the lowest: compounds 1, 2 and 4 (each within the scatter of the next, the first and the last beyond it). At a limit, above all of these: compound 3.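

In this assay, putting diethylamino in place of piperidin-1-yl gives an at least 1.2-fold lower number from compound 3 to compound 4 (0.08 log units; that floor lies within the scatter). Going by these compounds alone, the earlier amine swap joined two ring amines on the chloro compounds, whereas this one brings in an amine with no ring on a compound carrying hydrogen, and compound 4 gives a readable 82400 nM. Still, the true size of this step stays unknown, and no real gain can be claimed for the open-chain amine, because compound 3 sits at a limit: the limit of > 100000 nM in this assay, at which 1 of the 4 values shown sits.

The compounds shown leave open how diethylamino would read on the chloro version of this core, where compound 1 gives a true number to compare with. They also leave open what a morpholine, a dimethylamino group or a longer chain to the amine would do at this position.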